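Stability of compound 4 after a change at the chain carbon

The source may hold more compounds than are shown below. What is called first, only, known or untested is meant among the compounds shown, and "the series" means these compounds.

Compound 1 `C[C@@H](O)[C@H]1C(=O)N2C(C(=O)OCOC(=O)C3CCCCC3)=C(S[C@@H]3CN[C@H](C(=O)Nc4cccc(C(=O)O)c4)C3)[C@H](C)[C@H]12` gives > 95% in a physicochemical assay for metabolic stability, read by LC-MS, in phosphate buffer, with a stated time of 3 h, at pH 7.4, tested at 50 uM (a higher number here means that more of the compound is left, a lower number that less of the compound is left), which is a limit of the assay and not a number.
Compound 2 `CCOC(=O)C1=C(S[C@@H]2CN[C@H](C(=O)Nc3cccc(C(=O)O)c3)C2)[C@H](C)[C@@H]2[C@@H]([C@@H](C)O)C(=O)N12` gives > 95% in this assay, again a limit.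
Compound 3 `CC(C)OC(=O)OCOC(=O)C1=C(S[C@@H]2CN[C@H](C(=O)Nc3cccc(C(=O)O)c3)C2)[C@H](C)[C@@H]2[C@@H]([C@@H](C)O)C(=O)N12` gives > 95% in this assay, again a limit.

Compound 3 therefore stands at the top of what the measurement can report, together with the other two values, as the limit of > 95% in this assay, at which 3 of the 3 values shown sit, shows. The three measured steps, a step that the two limits leave unreadable from compound 1 to compound 2, a step that the two limits leave unreadable from compound 1 to compound 3 and a step that the two limits leave unreadable from compound 2 to compound 3, all run between limits, so none of them tells whether a change at this part of the shared core alters how much compound is left.

Compound 4 `C[C@@H](O)[C@H]1C(=O)N2C(C(=O)OCC(F)(F)F)=C(S[C@@H]3CN[C@H](C(=O)Nc4cccc(C(=O)O)c4)C3)[C@H](C)[C@H]12` differs from compound 3 in one place: trifluoromethyl in place of (isopropoxycarbonyl)oxy on a saturated chain carbon bound to an oxygen next to a carbonyl group. The measured steps bear on the same place, since each of them also exchanges a group on a saturated chain carbon bound to an oxygen next to a carbonyl group, yet each was unreadable. Among the measured compounds shown here, no direction can be read from them, and none of the measured compounds fell below the limit.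

Compound 4 is thus expected to sit at the limit as well, with an estimated step of a number no higher from compound 3 to compound 4 (the limit leaves the size open) from compound 3 to compound 4 in this assay, and an estimated value of 95%, between 85% and 100%.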

Compound 4, percent of the compound remaining: > 95%
Compound 4: no number, only a limit; the forecaster's own chance of this, stated with the estimate: 80%; the middle value lies on the limit itself.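

In this assay compound 4 gives > 95% and this is a limit of the assay, not a number. Its steps from compound 1, compound 2 and compound 3 therefore cannot be read, and the same holds across the series: the limit of > 95% in this assay, at which 4 of the 4 values shown sit. The compounds shown leave open whether exchanging the group on a saturated chain carbon bound to an oxygen next to a carbonyl group changes how much compound is left.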